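Nitro series notes: from compound 3 to compound 4

The source may hold more compounds than are shown below. What is called first, only, known or untested is meant among the compounds shown, and "the series" means these compounds.

Measured in a functional assay on SK-N-SH cells (Homo sapiens) for cytotoxicity, read by MTT assay, with a stated time of 24 h; on this read-out lower numbers stand for stronger inhibition and higher numbers for weaker inhibition:
- compound 1 `COc1cc(/C=C(\C#N)C(=O)N/N=C(\C)c2c(O)c3ccc(O)cc3oc2=O)ccc1O` gives 14400 nM
- compound 2 `COc1ccc(/C=C(\C#N)C(=O)N/N=C(\C)c2c(O)c3ccc(O)cc3oc2=O)cc1` gives 9460 nM
- compound 3 `C/C(=N\NC(=O)/C(C#N)=C/c1ccc([N+](=O)[O-])cc1)c1c(O)c2ccc(O)cc2oc1=O` gives 10300 nM

Compound 3 stands at 10300 nM, within the scatter of both other values, so these numbers put the three compounds in no order. The next structure is compound 4 `C/C(=N\NC(=O)/C(C#N)=C/c1ccccc1[N+](=O)[O-])c1c(O)c2ccc(O)cc2oc1=O`, and the change from compound 3 is 2-nitrophenyl in place of 4-nitrophenyl on a double-bonded chain carbon bound to a double-bonded chain carbon. In words, this is 2-nitrophenyl in place of 4-nitrophenyl on a double-bonded chain carbon bound to a double-bonded chain carbon.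

Going by the values given here, three measured steps concern this same place: a 1.5-fold lower number from compound 1 to compound 2 (0.18 log units; within the scatter), a 1.4-fold lower number from compound 1 to compound 3 (0.15 log units; within the scatter) and a 1.1-fold higher number from compound 2 to compound 3 (0.04 log units; within the scatter). All three lie within the scatter. Among the compounds with values here, no measured step exchanges 4-nitrophenyl for 2-nitrophenyl, so the data offer only an indirect guide to this change. Resting on a 1.1-fold higher number from compound 2 to compound 3 (0.04 log units; within the scatter) and the two other small steps, no step beyond the scatter is expected in this assay, and no direction is favoured. The expected outcome is a 1.0-fold higher number from compound 3 to compound 4 (0.01 log units; within the scatter). Compound 4 is estimated at 10500 nM, with an expected range from 5500 nM to 20000 nM.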

Compound 4, half-maximal inhibitory concentration: 12300 nM
Estimate against measurement, compound 4: 1.2-fold (0.07 log units) below; the range from low to high includes it.
By their numbers in this assay, from the lowest: compounds 2, 3, 4 and 1 (each within the scatter of the next).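

Going by these compounds alone, the exchange of 4-nitrophenyl for 2-nitrophenyl on a double-bonded chain carbon bound to a double-bonded chain carbon gives the first direct reading of where the nitro group sits on this ring: in this assay the result is a 1.2-fold higher number from compound 3 to compound 4 (0.08 log units; within the scatter) and so shows no readable effect of the rearrangement, with the same atoms joined differently. Within the data shown here, the 2-nitrophenyl compound also shows a 1.3-fold higher number from compound 2 to compound 4 (0.11 log units; within the scatter) and a 1.2-fold lower number from compound 1 to compound 4 (0.07 log units; within the scatter) so that, alongside the earlier steps, all four aryl groups now seen at this place fall in one band with no order among them, whether the ring carries hydroxy and methoxy, methoxy alone or nitro in either printed arrangement. No measurement offered here explains this flat picture.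

As far as these compounds go, it remains open whether any replacement at this place can produce a step beyond the scatter, for instance an aminophenyl or carboxyphenyl ring, or a longer alkyl chain in place of the aryl ring. From the compounds shown here alone, it is equally open whether changes elsewhere on the shared core, such as at its hydroxy groups or at the nitrile, would move the number in this assay more than these aryl exchanges do.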